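Cytotoxicity notes on compounds 1 to 4

The source may report more compounds than this note shows. Statements on the series, on what has been measured and on what is new or still open speak of the compounds shown alone.

Measured so far:
- Compound 1 `COc1cccc(N2CCN(CC(=O)N3CCN(c4nnc(-c5ccc(C)cc5)c(-c5ccc(C)cc5)n4)CC3)CC2)c1`: in an ADME assay on NIH3T3 cells (Mus musculus) for cytotoxicity, read by MTT assay, with a stated time of 24 h (on this read-out higher numbers stand for weaker inhibition and lower numbers for stronger inhibition), compound 1 gives > 866000 nM, which is a limit of the assay and not a number.
- Compound 2 `COc1ccc(-c2nnc(N3CCN(C(=O)CN4CCN(c5ccc([N+](=O)[O-])cc5)CC4)CC3)nc2-c2ccc(OC)cc2)cc1`: in this assay compound 2 gives > 801000 nM, again a limit of the assay.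
- Compound 3 `COc1ccccc1N1CCN(CC(=O)N2CCN(c3nnc(-c4ccc(Cl)cc4)c(-c4ccc(Cl)cc4)n3)CC2)CC1`: in this assay compound 3 gives 405000 nM.

Going by the values given here, compound 3 thus carries the only read number among the three; the other two values are limits, so no order among the three compounds can be stated.

Compound 4 `O=C(CN1CCN(c2ccc([N+](=O)[O-])cc2)CC1)N1CCN(c2nnc(-c3ccc(Cl)cc3)c(-c3ccc(Cl)cc3)n2)CC1` has not yet been measured. Relative to compound 3 the change is 4-nitrophenyl in place of 2-methoxyphenyl on an amine nitrogen in a ring, the rest of the molecule being unchanged.

Among the compounds with values here, no step between two measured compounds is available for this change. Compound 2, which also carries a 4-nitrophenyl on a ring nitrogen, sits at the limit of > 801000 nM in this assay, at which 1 of the 3 values shown sits, so the expected step from compound 3 to compound 4 in this assay is a 1.5-fold higher number from compound 3 to compound 4 (0.17 log units; within the scatter), toward weaker inhibition or nothing beyond the scatter, with a fair chance that only a limit is reported. For compound 4 in this assay the estimate is 600000 nM, expected between 250000 nM and 1500000 nM.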

Compound 4, half-maximal inhibitory concentration: > 789000 nM
Compound 4: a limit, no number; the forecaster's own chance of this, stated with the estimate: 50%; middle value at least 1.3-fold (0.11 log units) away from the limit.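

In this assay compound 4 is reported only as a limit of the assay, not as a number: the limit of > 789000 nM in this assay, at which 1 of the 4 values shown sits. Going by these compounds alone, this gives the first step at this position, on an amine nitrogen in a ring, where 4-nitrophenyl in place of 2-methoxyphenyl gives an at least 1.9-fold higher number from compound 3 to compound 4 (0.28 log units; that floor lies within the scatter). From the compounds shown here alone, with the shared core otherwise unchanged, the 4-nitrophenyl group therefore shows no sign of stronger inhibition than the 2-methoxyphenyl group, although the true size of the step remains unknown.

The compounds shown leave open how far the value of compound 4 lies past its limit, and whether the same change gives a similar step on a core carrying other aryl groups. Also open, going by these compounds, is how an aminophenyl or a carboxyphenyl group on the same ring nitrogen would read in this assay.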